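Swapping methyl for isopropyl on a low-toxicity quinolinone scaffold

The source may hold more compounds than are shown below. What is called first, only, known or untested is meant among the compounds shown, and "the series" means these compounds.

Measured so far:
- compound 1, `CC(C)c1ccc2[nH]c(=O)c(CN(Cc3ccc(F)cc3)Cc3ccc(C(C)(C)C)cc3)cc2c1`: 7900 nM
- compound 2, `Cc1ccc2[nH]c(=O)c(CN(Cc3ccc(SC(F)F)cc3)Cc3ccc(C(C)(C)C)cc3)cc2c1`: > 5000 nM
- compound 3, `Cc1ccc2[nH]c(=O)c(CN(Cc3ccc(C(C)(C)C)cc3)C(C)c3ccc(F)cc3)cc2c1`: > 33000 nM

All three were tested in a toxicity assay on MDCK cells (Canis lupus familiaris) for cytotoxicity, read by crystal violet staining, with a stated time of 48 h; on this read-out lower numbers stand for higher toxicity in this test and higher numbers for lower toxicity in this test. For compound 3 the read-out is a limit of the assay rather than a number, > 33000 nM, and this is the limit described by the limit of > 33000 nM in this assay, at which 1 of the 3 values shown sits. Compound 2 likewise reached only a limit, > 5000 nM, the one described by the limit of > 5000 nM in this assay, at which 1 of the 3 values shown sits. Because both ends sit at limits, the step that the two limits leave unreadable from compound 2 to compound 3 cannot be read. Among the compounds with values here, compound 1, which carries an isopropyl group on the shared core, is the only one with a measured number, 7900 nM.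

Compound 4, `CC(C)c1ccc2[nH]c(=O)c(CN(Cc3ccc(C(C)(C)C)cc3)C(C)c3ccc(F)cc3)cc2c1`, differs from compound 3 by isopropyl in place of methyl on an aromatic carbon. Within the data shown here, no measured step follows this exact change, so the expectation rests on compound 3 sitting at a limit and on compound 1 giving a number with the same isopropyl group. Compound 4 is therefore estimated at 20000 nM, within 5000 nM to 60000 nM, which is expected to mean a step of an at least 1.6-fold lower number from compound 3 to compound 4 (0.21 log units; that floor lies within the scatter) that may well again end at a limit rather than a number.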

Compound 4, half-maximal cytotoxic concentration: 13100 nM
For compound 4 the middle estimate is 1.5-fold (0.18 log units) above the measured one; the measured number falls inside the stated range.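

In this assay, the aromatic carbon that carries methyl or isopropyl now gives a step of readable size: isopropyl in place of methyl there gives an at least 2.5-fold lower number from compound 3 to compound 4 (0.40 log units; beyond the scatter). That size is only a floor, since compound 3 holds a limit of the assay rather than a number: the limit of > 33000 nM in this assay, at which 1 of the 4 values shown sits. With isopropyl on the shared core in both compounds, methyl in place of hydrogen on the saturated chain carbon bound to the amine nitrogen and an aromatic carbon gives a 1.7-fold higher number from compound 1 to compound 4 (0.22 log units; within the scatter), so this second change cannot be told apart from repeat-measurement scatter.

On these data alone, only methyl and isopropyl appear at this aromatic carbon, so it remains open whether ethyl, cyclopropyl or methoxy there would fall in line with either of them. Within the data shown here, the change from methyl to isopropyl also rests on the single pair of compound 3 and compound 4, which leaves open whether it would give a similar step with the other amine substituents, such as those of compound 1 and compound 2.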